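Cis and trans stilbene ureas and imidazolidinones on fibrosarcoma cells

A few compounds are considered here, and "the series" means these few. Any claim that something is new, unique, unknown or untested is made for them only; others in the source may bear on it.

Working notes. For the measured compounds named here, the only numbered value so far comes from compound 1 `CCNC(=O)Nc1ccc(/C=C\c2cc(OC)c(OC)c(OC)c2)cc1`: in a functional assay on HT-1080 cells (Homo sapiens) for inhibition, read by sulforhodamine B assay, with a stated time of 48 h (a higher number here means a weaker inhibitor, a lower number a stronger inhibitor), compound 1 gives 29000 nM. Compound 2 `O=C1NCCN1c1ccc(/C=C/c2cccc(Cl)c2)cc1` is reported in this assay only as a limit, > 20000 nM, so where compound 2 truly stands is not known; (the limit of > 20000 nM in this assay, at which 1 of the 2 values shown sits).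

Compound 3 `O=C1NCCN1c1ccc(/C=C\c2cccc(Cl)c2)cc1` is the next member and has not been measured in this assay. Its relation to compound 2 is the two compounds have the same atoms and bonds and differ only in configuration as drawn: 1 of 1 stereo elements differ; a double bond is drawn E in compound 2 and Z in compound 3. Going by the values given here, no measured pair in this set shares this change, so the size of the step from compound 2 to compound 3 in this assay cannot be read from the data; the expectation is a step beyond the scatter toward stronger inhibition, but its size is uncertain, and the only other Z compound, compound 1, is itself weak in this assay.

The step from compound 2 to compound 3 is estimated as an at least 4.0-fold lower number from compound 2 to compound 3 (0.60 log units; beyond the scatter). For compound 3 in this assay the estimate is 5000 nM, range 500 nM to 30000 nM.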

Compound 3, half-maximal inhibitory concentration: 35 nM
The estimate for compound 3 lay 140-fold (2.15 log units) above the measured number; the whole stated range lies above it.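

In this assay the configuration of the double bond proves decisive for this imidazolidinone with its chlorophenyl group, with an at least 570-fold lower number from compound 2 to compound 3 (2.75 log units; beyond the scatter). This is the first pair in the series that isolates that single change, and the result shows that configuration alone can carry a step of this size, as no group enters or leaves: the fact that compounds 2 and 3 differ only in the configuration as drawn The printed size is only a lower bound, as compound 2 has no exact number: the limit of > 20000 nM in this assay, at which 1 of the 3 values shown sits.

Only one pair of E and Z compounds is shown, so it remains open whether a step of this size also appears with the ethyl urea of compound 1. On these data alone, it also remains open how the Z compound responds when a nitrile or an amine takes the place of the chlorine.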